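The compounds below may be only part of what the source reports. "The series", "measured", "known", "first", "only" and "open" are said of these compounds alone.

Of the compounds shown here, three built on one shared core have been measured in a physicochemical assay for acid dissociation. Compound 1 `COc1ccc(Oc2ccc3c(NCCCNCc4cc(F)ccc4OC)ccnc3c2)cc1` gives 9.28, and compound 2 `COc1ccc(F)cc1CNCCCNc1ccnc2cc(Oc3ccc(F)cc3)ccc12` gives 9.28, so the step of no change at the digits printed from compound 1 to compound 2 (within the scatter). Compound 3 `CCC(CC)c1ccc2c(NCCCNCc3cc(F)ccc3OC)ccnc2c1` gives 9.47, the highest of the three numbers, although its distance to compound 1 and to compound 2 is within the scatter, so the three cannot be ordered with confidence. Compound 4 `COc1ccc(F)cc1CNCCCNc1ccnc2cc(Oc3ccccc3)ccc12` has not yet been measured. It differs from compound 3 in a single place: phenoxy in place of pentan-3-yl on an aromatic carbon. The measured steps that bear on this are those in which pentan-3-yl entered in place of 4-methoxyphenoxy or 4-fluorophenoxy, namely a number 0.19 log units higher from compound 1 to compound 3 (within the scatter) and a number 0.19 log units higher from compound 2 to compound 3 (within the scatter). Compound 4 goes the other way, with phenoxy entering where pentan-3-yl leaves, so the expected movement is small and, if anything, downward; for compound 4 the expected step is a number 0.19 log units lower from compound 3 to compound 4 (within the scatter). For compound 4 the estimate in this assay is 9.28, with a range from 9 to 9.55.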

Compound 4, acid dissociation constant: 9.28
The estimate for compound 4 equals the measured number at the digits printed; measured number inside the range.
By their numbers in this assay, from the lowest: compounds 1, 2, 4 and 3 (each within the scatter of the next).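

In this assay, exchanging the pentan-3-yl group for a phenoxy group gives a number 0.19 log units lower from compound 3 to compound 4 (within the scatter) and so adds a group with a six-membered aromatic ring and an oxygen, without a step beyond the scatter. The earlier compounds shown here all carried a substituted phenoxy or pentan-3-yl group, and the unsubstituted phenoxy now allows each substituent to be read alone: hydrogen in place of fluoro gives no change at the digits printed from compound 2 to compound 4 (within the scatter) and hydrogen in place of methoxy gives no change at the digits printed from compound 1 to compound 4 (within the scatter) on that outer ring. No measurement shown here accounts for these results. Still open, going by these compounds, is whether an amine or a carboxylic acid at this position would give a step beyond the scatter. A longer chain or a small methyl group there also remains an open case.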